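The source may report more compounds than this note shows. Statements on the series, on what has been measured and on what is new or still open speak of the compounds shown alone.

Compound 1 `O=C(CSc1snnc1-c1ccc(Br)cc1Br)Nc1ccccn1`, compound 2 `Cc1ccc(NC(=O)CSc2snnc2-c2ccc(Br)cc2Br)c([N+](=O)[O-])c1` and compound 3 `O=C(CSc1snnc1-c1ccc(Br)cc1Br)Nc1ccccc1F` share one core and differ only in the group on the amide-type nitrogen. In an ADME assay on MT4 cells (Homo sapiens) for cytotoxicity, read by MTT assay, with a stated time of 5 days (a higher number here means that more compound is tolerated, a lower number that less compound is tolerated), compound 1 gives 42400 nM. For compound 2 this assay returns only a limit, > 229000 nM. Compound 3 likewise stands at a limit in this assay, >= 27800 nM, so its place among the numbers shown cannot be fixed: it may sit near compound 1 or well beyond it. Going by the values given here, the one step that reaches it, a step that the limit leaves unreadable from compound 1 to compound 3, is therefore of unreadable size, as the limit of >= 27800 nM in this assay, at which 1 of the 3 values shown sits, records; the other limit, (the limit of > 229000 nM in this assay, at which 1 of the 3 values shown sits), belongs to a compound that is tolerated up to the top of the range tested.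

Compound 4 `Cc1ccc(NC(=O)CSc2snnc2-c2ccc(Br)cc2Br)c(Br)c1` is the next member, differing from compound 3 as follows: 2-bromo-4-methylphenyl in place of 2-fluorophenyl on an amide-type nitrogen. Among the compounds with values here, no measured step covers this change, and both values that could frame it are limits. Within the data shown here, the analyst therefore expects no step in this assay that can be read beyond the scatter, a step that the limit leaves unreadable from compound 3 to compound 4. For compound 4 the expected value in this assay is 60000 nM, within 20000 nM to 200000 nM, with a fair chance that only a limit is returned.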

Compound 4, half-maximal cytotoxic concentration: > 216000 nM
Compound 4 ended at the assay's limit (the forecaster's own chance of this, stated with the estimate: 50%); middle value at least 3.6-fold (0.55 log units) away from the limit.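

In this assay the group on the amide-type nitrogen now gives its first readable step, an at least 5.0-fold higher number from compound 1 to compound 4 (0.70 log units; beyond the scatter), with 2-bromo-4-methylphenyl in place of pyridin-2-yl, so on the phenyl side of this position more compound is tolerated than with the pyridin-2-yl group of compound 1. Compound 4 itself is held only at a limit of the assay, not at a number: the limit of > 216000 nM in this assay, at which 1 of the 4 values shown sits. The steps that join compound 4 to compound 2 and to compound 3 cannot be read, so neither bromo in place of nitro nor 2-bromo-4-methylphenyl in place of 2-fluorophenyl can be given a size.

The compounds shown leave open how far above its limit compound 4 lies, and which part of 2-bromo-4-methylphenyl goes with the step from compound 1. They also leave open how this assay would read with an amine or a carboxylic acid on the phenyl group, or with a longer chain on the amide-type nitrogen in place of the aromatic group.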